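Adding a chloro group to the core of compound 1

The source may report more compounds than this note shows. Statements on the series, on what has been measured and on what is new or still open speak of the compounds shown alone.

Measured compounds in a functional assay on MDA-MB-231 cells (Homo sapiens) for antiproliferative activity, read by MTT assay, with a stated time of 48 h; on this read-out higher numbers stand for weaker inhibition and lower numbers for stronger inhibition:
- compound 1 `CS(=O)(=O)c1ccc(Nc2ncc(F)c(Nc3nc4ccccc4s3)n2)cc1`: 4980 nM
- compound 2 `CS(=O)(=O)c1ccc(Nc2nccc(Nc3nc4ccccc4s3)n2)cc1`: 5910 nM
- compound 3 `Cc1ccc2nc(Nc3ccnc(Nc4ccc(S(N)(=O)=O)cc4)n3)sc2c1`: 3870 nM

Compound 1 stands second highest of the three numbers. Its nearest neighbour is compound 2, and the step of a 1.2-fold higher number from compound 1 to compound 2 (0.07 log units; within the scatter) lies within the scatter. Going by the values given here, compound 3 differs from compound 1 in more than one place, so no single step links them, and its value sits within the scatter of that of compound 1.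

Compound 4 `CS(=O)(=O)c1ccc(Nc2ncc(F)c(Nc3nc4ccc(Cl)cc4s3)n2)cc1` is not yet measured. It differs from compound 1 in one place: chloro in place of hydrogen on an aromatic carbon. Among the compounds with values here, no measured step concerns a chloro group, and the one step that is known, from compound 1 to compound 2, touches a different position and stays within the scatter. The three measured values all lie close together, whatever the change made. The expectation for compound 4 is therefore a step of a 1.2-fold lower number from compound 1 to compound 4 (0.10 log units; within the scatter) of no real size, no further than the scatter allows.

The estimate for compound 4 in this assay is 4000 nM, expected between 1500 nM and 12000 nM.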

Compound 4, half-maximal inhibitory concentration: 11100 nM
For compound 4 the middle estimate is 2.8-fold (0.44 log units) below the measured one, and the stated range covers the measured number.
By their numbers in this assay, from the lowest: compounds 3, 1, 2 and 4 (each within the scatter of the next, the first and the last beyond it).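

In this assay, going by these compounds alone, the change of hydrogen to chloro gives the first step in this set that lies beyond the scatter, a 2.2-fold higher number from compound 1 to compound 4 (0.35 log units; beyond the scatter), and a higher number here means weaker inhibition. Within the data shown here, the step is modest, but it shows that this aromatic carbon of the fused system is not indifferent to what it carries, whereas the one earlier step, the loss of fluoro at a different place, stayed within the scatter. Nothing shown here explains why the single chlorine atom has this effect.

One step at one carbon cannot show whether the weaker inhibition belongs to chloro alone or would also follow from another group there, such as an amine or a methoxy group. On these data alone, it also remains open whether chloro would give a step of similar size on the core of compound 2, which has no fluoro.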